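Swapping a Ring Carbon for Oxygen in Compound 2

The source may report more compounds than this note shows. Statements on the series, on what has been measured and on what is new or still open speak of the compounds shown alone.

In a physicochemical assay for lipophilicity, at pH 7.4 (on this read-out lower numbers stand for lower lipophilicity and higher numbers for higher lipophilicity), compound 1 (`O=C(O)c1ccc(NC(=O)[C@H](CC2CCCC2)n2cnc(S(=O)(=O)C3CC3)c2)nc1`) gives -0.2 and compound 2 (`O=C(O)c1ccc(NC(=O)[C@H](CC2CCCCC2)n2cnc(S(=O)(=O)C3CC3)c2)nc1`) gives -0.25 within the scatter of each other, while compound 3 (`O=C(O)c1ccc(NC(=O)[C@H](CC2CCCCC2)n2cnc(S(=O)(=O)C3CCC3)c2)nc1`) gives 0.15 on the higher side. Compound 2 therefore stands level with compound 1 and under compound 3.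

In compound 4 (`O=C(O)c1ccc(NC(=O)[C@H](CC2CCOCC2)n2cnc(S(=O)(=O)C3CC3)c2)nc1`) the change from compound 2 is oxan-4-yl in place of cyclohexyl on a saturated chain carbon, two bonds along the chain from an aromatic nitrogen and a carbonyl carbon and it sits on a saturated chain carbon, two bonds along the chain from an aromatic nitrogen and a carbonyl carbon. Oxan-4-yl thus replaces cyclohexyl.

The closest evidence comes from that same carbon, where cyclohexyl in place of cyclopentyl gave a number 0.05 log units lower from compound 1 to compound 2 (within the scatter) and left the number practically unmoved. Elsewhere, cyclobutyl in place of cyclopropyl on a sulfonyl sulfur gave a number 0.40 log units higher from compound 2 to compound 3 (beyond the scatter) as a modest rise. Among the compounds with values here, both of these steps exchange rings of carbon only, so neither sizes the entry of a ring oxygen and a hydrogen-bond acceptor, and the data hold no direct precedent for it.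

The expectation is still a fall clearly beyond the scatter and larger than either measured step. The estimated step is a number 0.85 log units lower from compound 2 to compound 4 (beyond the scatter) and this remains a judgement from the structural change alone. Compound 4 is expected at -1.1 with an estimated range of -1.6 to -0.7 for its measurement.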

Compound 4, distribution coefficient: -1.85
Compound 4: the middle estimate sits 0.75 log units above what was measured, and the stated range ends above it.
By their numbers in this assay, from the lowest: compound 4; then compounds 2 and 1 (each within the scatter of the next); then compound 3.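

In this assay, exchanging a single ring carbon for oxygen at this saturated chain carbon gives a number 1.60 log units lower from compound 2 to compound 4 (beyond the scatter) while the ring stays six-membered with the same count of heavy atoms, so the first measure of a ring hetero atom here is a large one. The change from cyclopentyl to oxan-4-yl tells the same story, with a number 1.65 log units lower from compound 1 to compound 4 (beyond the scatter), whereas the carbon-only change of ring size at this same carbon gave a number 0.05 log units lower from compound 1 to compound 2 (within the scatter); at this position, then, the identity of one ring atom counted for far more on this scale than the size of the carbon ring did. The measurements show the size of this step, but nothing available here accounts for it.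

As far as these compounds go, what remains open is whether the step belongs to oxygen in particular, since a ring nitrogen, as in piperidin-4-yl, or oxygen placed elsewhere in the ring, as in oxan-3-yl, could move the number by a different amount. From the compounds shown here alone, it is also open whether oxan-4-yl would give a similar step alongside the cyclobutyl on the sulfonyl sulfur of compound 3, or whether the size of the step depends on that partner group.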